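Swapping the Azole Partner: From Compound 2 to Compound 3

The source may hold more compounds than are shown below. What is called first, only, known or untested is meant among the compounds shown, and "the series" means these compounds.

Measured so far:
Compound 1, `CC(C)n1ncnc1-c1ccccc1NCC1=NCCN1`: 6.31 nM
Compound 2, `c1ccc(-c2cn[nH]c2)c(NCC2=NCCN2)c1`: 1.26 nM

Of the compounds shown here, two have been tested in an in vitro functional assay on cells (Fibroblast) for agonist activity at Alpha-1A adrenergic receptor (Homo sapiens); a higher number here means that more compound is needed for the effect, a lower number that less compound is needed. Compound 2 gives 1.26 nM, the lowest of the two numbers; its nearest neighbour is compound 1 with 6.31 nM, a gap that lies beyond the scatter. Among the measured compounds shown here, no pair of compounds differing in one place has been measured, so there is no measured step to lean on.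

Compound 3, `Cn1ccnc1-c1ccccc1NCC1=NCCN1`, is not yet measured. It differs from compound 2 in one place: 1-methyl-1H-imidazol-2-yl in place of 1H-pyrazol-4-yl on an aromatic carbon. For the measured compounds named here, the only guide is that compound 1, at 6.31 nM, shows that a change in the five-membered ring can shift the number beyond the scatter, and in the direction of more compound being needed. Compound 3 is therefore expected to sit above compound 2, with an estimated step of a 3.2-fold higher number from compound 2 to compound 3 (0.50 log units; beyond the scatter) in this assay. The estimate for compound 3 is 4 nM, with a range from 1.5 nM to 12 nM.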

Compound 3, half-maximal effective concentration: 6.31 nM
For compound 3 the middle estimate is 1.6-fold (0.20 log units) below the measured one, within the range that was stated.
By their numbers in this assay, from the lowest: compound 2; then compounds 1 and 3 (each within the scatter of the next).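

In this assay, among the compounds shown here, replacing 1H-pyrazol-4-yl with 1-methyl-1H-imidazol-2-yl on an aromatic carbon gives a 5.0-fold higher number from compound 2 to compound 3 (0.70 log units; beyond the scatter), the first measured one-place step in this set. It shows that the number at this position depends on which five-membered aromatic ring is attached, even though both rings carry 2 hetero atoms. The entering group also has 0 hydrogen-bond donors against 1 and 2 hydrogen-bond acceptors against 1, but no measurement here bears on why the number rises.

The compounds shown leave open whether the step follows from the added methyl group or from the change of ring and its point of attachment, which a 1H-imidazol-2-yl or 1-methyl-1H-pyrazol-4-yl group would separate. They also leave open how a six-membered ring such as pyridyl, or an open-chain amine, would behave at this position.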